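Trifluoromethyl for Chloro on the Aryl Ether of Compound 2

A few compounds are considered here, and "the series" means these few. Any claim that something is new, unique, unknown or untested is made for them only; others in the source may bear on it.

Of the compounds shown here, three that share one core have been measured in an ADME assay on microsomes from liver (Mus musculus) for metabolic stability, read by LC-MS, using NADPH, tested at 1 uM; a higher number here means that the compound lasts longer, a lower number that the compound disappears faster. Compound 1 `Cc1cnc(NC(=O)CCCOc2cncc(Cl)c2)s1` gives 0.1 h in this assay. Compound 2 `N#Cc1cnc(NC(=O)CCCOc2cccc(Cl)c2)s1` gives 0.133 h in this assay. Compound 3 `Cc1cnc(NC(=O)CCCOc2cccc(C#N)c2)s1` gives 0.0667 h in this assay. Compound 2 has the highest of the three numbers, but its gaps to compound 1 and to compound 3 both lie within the usual scatter, so no order among the three can be drawn from these values.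

The next compound, compound 4 `N#Cc1cnc(NC(=O)CCCOc2cccc(C(F)(F)F)c2)s1`, differs from compound 2 in one place: trifluoromethyl in place of chloro on an aromatic carbon. Within the data shown here, no measured pair in this set shows this particular exchange, so no step size can be read from the data. The three measured values sit close together, and nothing among them points in either direction for this change. Compound 4 is expected to remain in the same region, with a step of a 1.1-fold higher number from compound 2 to compound 4 (0.05 log units; within the scatter) that stays within the scatter. The estimate for compound 4 in this assay is 0.15 h, within a range from 0.07 h to 0.35 h.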

Compound 4, half-life: 0.517 h
Beside the measured number, compound 4's estimate is 3.4-fold (0.54 log units) below it; the whole stated range lies below it.
By their numbers in this assay, from the lowest: compounds 3, 1 and 2 (each within the scatter of the next); then compound 4.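

In this assay, trifluoromethyl in place of chloro on this aromatic carbon gives a 3.9-fold higher number from compound 2 to compound 4 (0.59 log units; beyond the scatter), and that step lies beyond the scatter. Among these compounds, compounds 1, 2 and 3 offered no pair differing in one place, so this is the first sign that the number responds to the group at this position of the aryl ether, although the sign rests on a single pair. Nothing available here bears on why the number rises with this exchange.

As far as these compounds go, it remains open whether another group on the same aromatic carbon, such as fluoro, methoxy or tert-butyl, would give a step of similar size. From the compounds shown here alone, it is also open whether the exchange would give the same step with the methyl of compound 1 and compound 3 in place of the nitrile of compound 2.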